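The source may report more compounds than this note shows. Statements on the series, on what has been measured and on what is new or still open speak of the compounds shown alone.

Within the data shown here, in a functional assay on MDA-MB-231 cells (Homo sapiens) for antiproliferative activity, read by sulforhodamine B assay, with a stated time of 48 h (a higher number here means a weaker inhibitor, a lower number a stronger inhibitor), compound 1 `COc1ccc2nc(-c3ccc(N/C=C\C(=O)c4ccc(OC)c(O)c4)cc3)sc2c1` gives 18900 nM and compound 2 `COc1ccc2nc(-c3ccc(N/C=C\C(=O)c4ccc(OC)c([N+](=O)[O-])c4)cc3)sc2c1` gives 17600 nM, so compound 2 stands level with the only other measured compound. The next structure, compound 3 `COc1ccc2nc(-c3ccc(N/C=C\C(=O)c4ccc(OC)c(F)c4)cc3)sc2c1`, carries fluoro in place of nitro on an aromatic carbon. Among the measured compounds shown here, only one measured step bears on this change, a 1.1-fold lower number from compound 1 to compound 2 (0.03 log units; within the scatter), which put nitro in place of hydroxy on an aromatic carbon and stayed within the scatter. With so little evidence, no shift beyond the scatter is expected in this assay, and the expected step is a 1.0-fold lower number from compound 2 to compound 3 (0.02 log units; within the scatter). Compound 3 is estimated at 17000 nM, with an expected range of 8000 nM to 35000 nM.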

Compound 3, half-maximal inhibitory concentration: 1100 nM
Compound 3: the middle estimate sits 15-fold (1.19 log units) above what was measured, and the stated range ends above it.
By their numbers in this assay, from the lowest: compound 3; then compounds 2 and 1 (each within the scatter of the next).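

Compounds 1 and 2 stand level, so hydroxy and nitro alone gave no sign that this aromatic carbon, ortho to a methoxy group, matters. Fluoro shows that it does: in this assay the change from nitro gives a 16-fold lower number from compound 2 to compound 3 (1.20 log units; beyond the scatter) and the change from hydroxy gives a 17-fold lower number from compound 1 to compound 3 (1.24 log units; beyond the scatter) on the same carbon. Nothing measured here explains why fluoro stands apart.

Going by these compounds, whether this gain is particular to fluoro remains open. Chloro, methyl or an amine on this carbon would show whether other groups match it.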